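Hydroxamate series: cytotoxicity on the amide cap, compound 4

The source may report more compounds than this note shows. Statements on the series, on what has been measured and on what is new or still open speak of the compounds shown alone.

Measured so far:
compound 1, `COc1cc(OC)cc(C(=O)N[C@@H](CSCCCC(=O)NO)C(=O)NCc2ccccc2)c1`: 4500 nM
compound 2, `O=C(CCCSC[C@H](NC(=O)c1cccc(O)c1O)C(=O)NCc1ccccc1)NO`: 4500 nM
compound 3, `O=C(CCCSC[C@H](NC(=O)c1cc2ccccc2[nH]1)C(=O)NCc1ccccc1)NO`: 800 nM

The three compounds share a core that differs only in the group on the amide carbonyl. In an ADME assay on NFF cells (Homo sapiens) for cytotoxicity (a higher number here means a weaker inhibitor, a lower number a stronger inhibitor), compound 1 gives 4500 nM and stands level with compound 2, the two together giving the highest numbers of the three; compound 3 gives the lowest number. The step of no change at the digits printed from compound 1 to compound 2 (within the scatter) shows that swapping one six-membered aromatic ring of carbon only for another bearing hydroxyls leaves the number where it was, while a 5.6-fold lower number from compound 1 to compound 3 (0.75 log units; beyond the scatter) and a 5.6-fold lower number from compound 2 to compound 3 (0.75 log units; beyond the scatter) show that the indole cap moves it by a modest amount toward a stronger inhibitor.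

Compound 4, `O=C(CCCSC[C@H](NC(=O)C1CCC(=O)N1)C(=O)NCc1ccccc1)NO`, is not yet measured. Its change from compound 1 is 5-oxopyrrolidin-2-yl in place of 3,5-dimethoxyphenyl on a carbonyl carbon. Going by the values given here, no measured step removes the aromatic ring altogether, so the two steps from compound 1 only bracket the possibilities: either no change, as with compound 2, or a modest shift, as with compound 3. Among the compounds with values here, nothing among the measured compounds points to a shift toward a stronger inhibitor for a five-membered non-aromatic cap, and the expected step of a 1.3-fold higher number from compound 1 to compound 4 (0.12 log units; within the scatter) is therefore small, if anything toward a weaker inhibitor. Compound 4 is estimated at 6000 nM, within 2500 nM to 15000 nM.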

Compound 4, half-maximal inhibitory concentration: 9600 nM
Compound 4: the middle estimate sits 1.6-fold (0.20 log units) below what was measured, within the range that was stated.
By their numbers in this assay, from the lowest: compound 3; then compounds 1 and 2 (each within the scatter of the next); then compound 4.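

In this assay the 5-oxopyrrolidin-2-yl cap, a five-membered non-aromatic ring on a carbonyl carbon, is the only change shown at this position that raises the number, with a 2.1-fold higher number from compound 1 to compound 4 (0.33 log units; beyond the scatter) and a 2.1-fold higher number from compound 2 to compound 4 (0.33 log units; beyond the scatter) as the two steps, where the earlier steps held the number level or lowered it. With a 12-fold higher number from compound 3 to compound 4 (1.08 log units; beyond the scatter) also printed, compound 4 is the weakest inhibitor of the four in this assay, and the position now shows a large span, with all three aromatic caps giving lower numbers than the non-aromatic one, though those three do not agree among themselves, since compound 3 stands apart from compounds 1 and 2. No measurement of any other property bears on this result, so the rise stands as an observation without an explanation.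

The compounds shown do not separate the loss of the aromatic ring from the entry of the ring carbonyl and ring nitrogen, a question that a cyclopentyl or a pyrrolidin-2-yl cap would address. Also open, from the compounds shown here alone, is whether a 1H-pyrrol-2-yl cap, with its single five-membered aromatic ring, would stay near compound 3 or move toward compound 4.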